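Pyridine to Pyrazole on the Shared Core

The compounds below may be only part of what the source reports. "The series", "measured", "known", "first", "only" and "open" are said of these compounds alone.

In a functional assay on a cell-free system (plasma) with sterol O-acyltransferase, Soat (Rattus norvegicus) as the target (on this read-out lower numbers stand for an effect already at smaller amounts and higher numbers for an effect only at larger amounts of compound), compound 3 `Cc1cc(C)c(NC(=O)N(Cc2ccc(-c3ccccn3)cc2)C2CCCCCC2)c(C)c1` sits at a limit of the assay, > 1 mg/kg. Compound 2 `Cc1cc(C)c(NC(=O)N(Cc2ccc(-c3ccsc3)cc2)C2CCCCCC2)c(C)c1` gives 0.51 mg/kg in this assay. Compound 1 `Cc1cc(C)c(NC(=O)N(Cc2ccc(-c3n[nH]c(C)n3)cc2)C2CCCCCC2)c(C)c1` also sits at a limit, > 1 mg/kg. Compound 4 `Cc1cc(C)c(NC(=O)N(Cc2ccc(-c3ccn(C)n3)cc2)C2CCCCCC2)c(C)c1` is not yet measured and differs from compound 3 in one place: 1-methyl-1H-pyrazol-3-yl in place of pyridin-2-yl on an aromatic carbon. Going by the values given here, two measured steps bear on this: an at least 1.9-fold higher number from compound 2 to compound 3 (0.29 log units; that floor lies within the scatter), and an at least 1.9-fold lower number from compound 1 to compound 2 (0.29 log units; that floor lies within the scatter), while a step that the two limits leave unreadable from compound 1 to compound 3. The 1-methyl-1H-pyrazol-3-yl resembles the 5-methyl-1H-1,2,4-triazol-3-yl of compound 1 more than the thiophen-3-yl of compound 2, and compound 1 sits at the limit of > 1 mg/kg in this assay, at which 2 of the 3 values shown sit. Compound 4 is therefore expected to show a step that the limit leaves unreadable from compound 3 to compound 4. Compound 4 is estimated at 1.5 mg/kg, within a range from 0.5 mg/kg to 5 mg/kg.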

Compound 4, dose for half-maximal effect: < 1 mg/kg
Compound 4 was reported as a limit (the forecaster's own chance of this, stated with the estimate: 65%); middle value at least 1.5-fold (0.17 log units) from the limit.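

In this assay, compound 4 is reported as a limit and not as a number: the limit of < 1 mg/kg in this assay, at which 1 of the 4 values shown sits. The change gives a number no higher from compound 3 to compound 4 (the limit leaves the size open), and the triazole swap gives a number no higher from compound 1 to compound 4 (the limit leaves the size open). At this place, para to a large group, thiophen-3-yl is thus no longer the only ring shown to escape the upper limit, while the five-membered ring of compound 1 does not.

Going by these compounds, the step between compound 2 and compound 4 cannot be read, so how these two rings rank stays open. Also open, on these data alone, is what an open-chain group at this place, such as an amine or a carboxylic acid, would give.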